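A few compounds are considered here, and "the series" means these few. Any claim that something is new, unique, unknown or untested is made for them only; others in the source may bear on it.

Going by the values given here, in a functional assay on HL-60 cells (Homo sapiens) for cytotoxicity, read by MTT assay, with a stated time of 46 h (on this read-out lower numbers stand for stronger inhibition and higher numbers for weaker inhibition), three compounds have numbers so far. Compound 1 (`O=C1/C(=C/c2ccncc2)C(c2ccccc2)Oc2ccccc21`) gives 900 nM and compound 2 (`O=C1/C(=C\c2ccccc2)C(c2ccccc2)Oc2ccccc21`) gives 27300 nM on this read-out. Compound 3 (`N#Cc1ccc(Cc2coc3ccccc3c2=O)cc1`) gives 3800 nM and so holds the middle place of the three. Its number is separated from both others by more than the usual scatter, lying closer to compound 1 and further from compound 2.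

Compound 4 (`O=c1c(Cc2ccc(F)cc2)coc2ccccc12`) has not been measured yet. It differs from compound 3 in one place (fluoro in place of cyano on an aromatic carbon), with fluoro in place of cyano on an aromatic carbon, para to a large group. Among the compounds with values here, no measured pair here differs in just one place, so nothing shows directly what such a swap does. The best anchor is therefore compound 3 itself (3800 nM), and the range has to stay wide. The expected change is no step beyond the scatter, and the estimated step is a 1.3-fold higher number from compound 3 to compound 4 (0.12 log units; within the scatter) in this assay. For compound 4 the estimated value is 5000 nM (expected range 1800 nM to 14000 nM).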

Compound 4, half-maximal inhibitory concentration: 19100 nM
Compound 4: middle estimate off by 3.8-fold (0.58 log units), on the low side; measured number above the stated range.
By their numbers in this assay, from the lowest: compound 1; then compound 3; then compounds 4 and 2 (each within the scatter of the next).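

In this assay, this is the first swap in one place among the compounds shown, and it gives a 5.0-fold higher number from compound 3 to compound 4 (0.70 log units; beyond the scatter). The carbon of the aromatic ring para to a large group is therefore not indifferent to what sits on it, and exchanging cyano for fluoro is enough to move the number beyond the scatter. Nothing measured here accounts for this difference.

Going by these compounds, with only these two groups at this carbon, it remains open whether cyano strengthens inhibition or fluoro weakens it, and a compound with plain hydrogen there would help to separate the two. On these data alone, it also remains open whether a methoxy group, an amine or a carboxylic acid at the same carbon would match compound 3 or fall closer to compound 4.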